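The compounds below may be only part of what the source reports. "The series", "measured", "known", "first", "only" and "open" are said of these compounds alone.

Measured in a functional assay on the whole organism (strain Kunming) for inhibition, with Mus musculus as the target, with a stated time of 1 h, at a dose of 40 mg/kg by the oral route; a higher number here means more inhibition at the dose given (going by the name of the read-out), a lower number less inhibition:
compound 1, `COc1cccc(N2CCN(c3ccc(C(=O)/C=C/c4ccccc4)cc3)CC2)c1`, gives 16%.
compound 2, `O=C(/C=C/c1ccccc1)c1ccc(N2CCN(c3ccccc3Cl)CC2)cc1`, gives 4.71%.
compound 3, `O=C(/C=C/c1ccccc1)c1ccc(N2CCN(c3cccc(C(F)(F)F)c3)CC2)cc1`, gives 25%.

Compound 1 stands second of the three; the step of a number 9 percentage points higher from compound 1 to compound 3 (within the scatter) lies within the scatter, while the step of a number 11.3 percentage points lower from compound 1 to compound 2 (beyond the scatter) lies beyond it, as does a number 20.3 percentage points higher from compound 2 to compound 3 (beyond the scatter). Compound 4, `COc1cccc(N2CCN(c3ccc(C(=O)/C=C/c4ccc(Cl)cc4)cc3)CC2)c1`, differs from compound 1 by chloro in place of hydrogen on an aromatic carbon. Within the data shown here, none of the measured steps touches this part of the shared core; all three change the aryl group on the amine nitrogen in the ring. Among the measured compounds shown here, no measured step therefore bears directly on the change. In this assay the expected step is estimated as a number 2 percentage points higher from compound 1 to compound 4 (within the scatter). Compound 4 is estimated at 18%, from 5% to 32%.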

Compound 4, a percentage reported as inhibition, in the whole organism at one dose (the size of the read-out at that dose, not a potency): 2.28%
Compound 4: the middle estimate sits 15.7 percentage points above what was measured, and the stated range ends above it.
By their numbers in this assay, from the lowest: compounds 4 and 2 (each within the scatter of the next); then compounds 1 and 3 (each within the scatter of the next).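

Going from phenyl to 4-chlorophenyl gives a number 13.7 percentage points lower from compound 1 to compound 4 (beyond the scatter) in this assay and so shows that this end of the molecule also bears on the read-out. The earlier compounds shown here changed only the aryl group on the amine nitrogen and could not show this. Nothing available here accounts for the drop. From the compounds shown here alone, whether it belongs to chloro alone stays open, since a methoxy, a methyl or an amine at this same place would separate chloro from substitution in general. Also open, going by these compounds, is whether chloro here acts the same way on compound 3.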